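The source may hold more compounds than are shown below. What is called first, only, known or untested is meant among the compounds shown, and "the series" means these compounds.

Working notes on the series. In a functional assay on HT-29 cells (Homo sapiens) for cytotoxicity, read by fluorescence and resazurin assay, with a stated time of 48 h (a lower number here means a stronger inhibitor, a higher number a weaker inhibitor), compound 1 `COc1cc(/C=C/c2cc(/C=C/c3cc(OC)c(OC)c(OC)c3)nc(OCCCCCCBr)n2)cc(OC)c1OC` gives only a limit of the assay, > 20000 nM, and no number. Compound 2 `BrCCCCOc1nc(/C=C/c2ccccc2)cc(/C=C/c2ccccc2)n1`, a relative on the same core, in this assay likewise gives only a limit, > 20000 nM. So compound 1 stands where every value shown stands: at the limit of > 20000 nM in this assay, at which 2 of the 2 values shown sit. Going by the values given here, no step between measured compounds can be read from this, since neither value is a number.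

Compound 3 `COc1cc(/C=C/c2cc(/C=C/c3cc(OC)c(OC)c(OC)c3)nc(OCCCCCBr)n2)cc(OC)c1OC` differs from compound 1 by a single change, (bromo in place of bromomethyl on a saturated chain carbon, five bonds along the chain from an oxygen on an aromatic ring). With both measured compounds at the limit, nothing in the data gives a direction for this change. The step expected in this assay, a step that the limit leaves unreadable from compound 1 to compound 3, is none beyond the scatter, and the likeliest outcome is that compound 3 again returns only a limit. Compound 3 is estimated at 30000 nM, within a range from 10000 nM to 100000 nM.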

Compound 3, half-maximal inhibitory concentration: > 20000 nM
Compound 3 gave a limit, no number (the forecaster's own chance of this, stated with the estimate: 85%); the middle value is on the limit's open side.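

Compound 3, like compound 1, returns only a limit in this assay, so no step between compound 1 and compound 3 can be read: the limit of > 20000 nM in this assay, at which 3 of the 3 values shown sit.

What the compounds shown leave open is whether any change to the chain or the shared core brings a measurable value in this assay.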